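Trifluoromethyl for Butyl on the Sulfonyl Aryl Ring

This account rests on a few compounds, and the source may have more. Where it says the series, first, only, none or still open, it means among the compounds named here.

Compound 1, `CCCCc1ccc(S(=O)(=O)NCCCCCCNCc2ccc(Br)cc2)cc1`: 5700 nM
Compound 2, `O=S(=O)(NCCCNCc1ccc(Cl)cc1)c1cc(C(F)(F)F)cc(C(F)(F)F)c1`: 2800 nM
Compound 3, `O=S(=O)(NCCCNCc1ccc(C(F)(F)F)cc1)c1cc(C(F)(F)F)cc(C(F)(F)F)c1`: 2500 nM

In a functional assay on MIA PaCa-2 cells (Homo sapiens) for inhibition, read by MTT assay, with a stated time of 72 h (a higher number here means a weaker inhibitor of growth, a lower number a stronger inhibitor of growth), compound 1 gives 5700 nM, the highest of the three numbers; both compound 2 and compound 3 lie beyond the scatter below it, compound 2 being the nearer of the two. Compound 4, `O=S(=O)(NCCCCCCNCc1ccc(Br)cc1)c1ccc(C(F)(F)F)cc1`, differs from compound 1 in one place: trifluoromethyl in place of butyl on an aromatic carbon.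

Among the measured compounds shown here, only one measured step bears on this change, and only loosely. Between compound 2 and compound 3 a trifluoromethyl took the place of a chloro, but on the other aromatic ring of the shared core and in a pair with a shorter chain; that step was a 1.1-fold lower number from compound 2 to compound 3 (0.05 log units; within the scatter). For the measured compounds named here, no measured pair exchanges butyl for trifluoromethyl, and none alters the ring that carries the sulfonyl group, so the account has no direct precedent for the step from compound 1 to compound 4.

On this basis the step is expected to fall within the scatter, a 1.3-fold lower number from compound 1 to compound 4 (0.10 log units; within the scatter), with no direction that can be called out. Compound 4 is therefore estimated at 4500 nM, with a range from 2000 nM to 10000 nM.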

Compound 4, concentration for 50% growth inhibition: 3830 nM
Estimate against measurement, compound 4: 1.2-fold (0.07 log units) above, and the stated range covers the measured number.
By their numbers in this assay, from the lowest: compounds 3, 2, 4 and 1 (each within the scatter of the next, the first and the last beyond it).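

In this assay, the ring that carries the sulfonyl group now has a measured step of its own: trifluoromethyl in place of butyl, on an aromatic carbon para to a large group, gives a 1.5-fold lower number from compound 1 to compound 4 (0.17 log units; within the scatter) and leaves the number within the scatter. The earlier step could not show this, since it changed the other aromatic ring and exchanged chloro rather than butyl. Butyl and trifluoromethyl each bring 4 heavy atoms and neither brings a ring, a hydrogen-bond donor or acceptor, or a net charge, but nothing measured here explains the size of this step or ties it to any property of either group.

From the compounds shown here alone, whether an amine, a carboxylic acid or a longer alkyl chain at this same position would carry the number beyond the scatter remains open. Also open, going by these compounds, is whether the exchange of butyl for trifluoromethyl would give a similar step on a core with the shorter chain of compound 2 and compound 3, or with a chloro in place of the bromo of compound 1.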